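The source may report more compounds than this note shows. Statements on the series, on what has been measured and on what is new or still open speak of the compounds shown alone.

Compound 1 `N#CC1=C(N)Oc2c(c3nc4ccccc4nc3c3ccccc23)C12C(=O)N(Cc1cnnn1-c1ccc(F)c(Cl)c1)c1ccccc12` and compound 2 `N#CC1=C(N)Oc2c(c3nc4ccccc4nc3c3ccccc23)C12C(=O)N(Cc1cnnn1-c1ccc(Cl)c(Cl)c1)c1ccccc12` share one core, while compound 3 `N#CC1=C(N)Oc2c(N)cc3nc4ccccc4nc3c2C12C(=O)N(Cc1cnnn1-c1ccc(F)cc1)c1ccccc12` and compound 4 `N#CC1=C(N)Oc2c(N)cc3nc4ccccc4nc3c2C12C(=O)N(Cc1cnnn1-c1ccc(Cl)cc1)c1ccccc12` share another; the difference between the two cores is not broken down here. In an ADME assay on L02 cells (Homo sapiens) for antiproliferative activity, read by MTT assay, with a stated time of 48 h (on this read-out lower numbers stand for stronger inhibition and higher numbers for weaker inhibition), compound 1 gives > 50000 nM, which is a limit of the assay and not a number. In this assay compound 2 likewise gives > 50000 nM, again a limit. Compound 3 gives > 50000 nM in this assay, once more a limit.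

The change from compound 1 to compound 2 is chloro in place of fluoro on an aromatic carbon. The step it made, a step that the two limits leave unreadable from compound 1 to compound 2, cannot be sized because both values sit at the limit of > 50000 nM in this assay, at which 3 of the 3 values shown sit. The change from compound 3 to compound 4 is chloro in place of fluoro on an aromatic carbon. It is the same kind of change, but the surroundings differ: in compound 1 the place is ortho to a chloro group, whereas in compound 3 the place is only para to a large group.

Compound 4 has not yet been tested in this assay. A step that the limit leaves unreadable from compound 3 to compound 4 is expected, which rests on the earlier change having produced a step that the two limits leave unreadable from compound 1 to compound 2 with both values at the same limit, and on compound 3 itself giving > 50000 nM. Compound 4 is therefore expected to give roughly 60000 nM in this assay, most likely reported only as a limit.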

Compound 4, half-maximal inhibitory concentration: > 50000 nM
Compound 4 was reported as a limit; the forecaster's own chance of this, stated with the estimate: 85%; the middle value is on the limit's open side.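

No size can be read for the change from fluoro to chloro between compound 3 and compound 4, and the same holds for compound 1 and compound 2, since each pair offers only limits and no numbers: the limit of > 50000 nM in this assay, at which 4 of the 4 values shown sit. The compounds shown leave open how far apart any of them truly lie in this assay, and whether the change from 4-fluorophenyl to 4-chlorophenyl has any effect there.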